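This account rests on a few compounds, and the source may have more. Where it says the series, first, only, none or still open, it means among the compounds named here.

Working notes on the series

Three compounds sharing one core have been run in a functional assay on the whole organism (strain albino) for inhibition, with Rattus norvegicus as the target, read by paw edema, with stated times of 30 min and 2 h, at a dose of 100 mg/kg by the oral route; a higher number here means more inhibition at the dose given (going by the name of the read-out), a lower number less inhibition. Compound 1 `COc1ccc(C2=NNC(c3ccco3)C2)cc1OC` gives 53% in this assay. Compound 2 `COc1ccc(C2CC(c3ccc(OC)c(OC)c3)=NN2)c(OC)c1` gives 39%, and compound 3 `COc1ccc(C2=NNC(c3c(Cl)cccc3Cl)C2)cc1OC` gives 49%. Compound 1 holds the largest of the three numbers; its gap to compound 3 lies within the scatter of repeated measurements, so no order between those two can be read, while its gap to compound 2 lies beyond the scatter. Among the compounds with values here, no pair among the three differs in a single place, so no measured step is at hand to gauge what one change at a time does to the read-out.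

The untested member is compound 4 `COc1ccc(C2=NN(C(=O)CO[N+](=O)[O-])C(c3ccco3)C2)cc1OC`. Set against compound 1 it carries ((nitrooxy)methyl)carbonyl in place of hydrogen on an amine nitrogen in a ring. Within the data shown here, the only anchor for what this change does is compound 1 itself, and nothing among the measured compounds tells how a change on that ring nitrogen moves the inhibition. The step from compound 1 to compound 4 is therefore expected to be small, a number 3 percentage points higher from compound 1 to compound 4 (within the scatter), in no direction that can be told from the scatter. Compound 4 is estimated at 56% in this assay, with a range from 40% to 72%.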

Compound 4, a percentage reported as inhibition, in the whole organism at one dose (the size of the read-out at that dose, not a potency): 37%
For compound 4 the middle estimate is 19 percentage points above the measured one; measured number below the stated range.
By their numbers in this assay, from the lowest: compounds 4, 2, 3 and 1 (each within the scatter of the next, the first and the last beyond it).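

Within the data shown here, the step of a number 16 percentage points lower from compound 1 to compound 4 (beyond the scatter) in this assay is the first measured change at this position, since compounds 1, 2 and 3 all keep hydrogen on the amine nitrogen in the ring. It shows that this nitrogen is not indifferent to substitution: with ((nitrooxy)methyl)carbonyl in place of hydrogen, inhibition at the dose given falls by more than the scatter, at least when the neighbouring ring atom bears the furan-2-yl group. Nothing measured on the compounds shown accounts for this fall, and the finding rests on this single pair.

Still open, as far as these compounds go, is which part of the entering group goes with the lower number, the carbonyl on the ring nitrogen or the nitrooxy end; a plain acetyl group or a hydroxyacetyl group on the same nitrogen would separate the two. Also open, from the compounds shown here alone, is whether the same replacement on compound 3, which carries a dichlorophenyl group in place of the furan-2-yl group, would move the read-out in the same direction and by a similar amount.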